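This account rests on a few compounds, and the source may have more. Where it says the series, first, only, none or still open, it means among the compounds named here.

Compound 2 `Cc1ccccc1Oc1ccc(CC2SC(=O)NC2=O)cc1` gives 124 nM in a functional assay for agonist activity at Free fatty acid receptor 1 (Homo sapiens), read by FLIPR, in the presence of a further agent that is not named here (a higher number here means that more compound is needed for the effect, a lower number that less compound is needed), the lower of the two numbers measured; compound 1 `O=C1NC(=O)C(Cc2ccc(Oc3ccccc3)cc2)S1` gives 307 nM. Within the data shown here, the one measured step, a 2.5-fold lower number from compound 1 to compound 2 (0.39 log units; beyond the scatter), is modest. Compound 3 `O=C1NC(=O)C(Cc2ccc(Oc3cccc(Cl)c3)cc2)S1` carries 3-chlorophenyl in place of 2-methylphenyl on an oxygen on an aromatic ring. Among the measured compounds shown here, no measured step bears on a chlorine on this ring; the methyl step shows only the scale of what a small change there has done. The number for compound 3 is therefore expected to shift little, by a 1.6-fold higher number from compound 2 to compound 3 (0.21 log units; within the scatter), giving an estimate of 200 nM with a range from 70 nM to 600 nM.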

Compound 3, half-maximal effective concentration: 318 nM
Beside the measured number, compound 3's estimate is 1.6-fold (0.20 log units) below it; the measured number falls inside the stated range.
By their numbers in this assay, from the lowest: compound 2; then compounds 1 and 3 (each within the scatter of the next).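

Among these compounds, the change of 2-methylphenyl to 3-chlorophenyl in this assay gives a 2.6-fold higher number from compound 2 to compound 3 (0.41 log units; beyond the scatter), which is the first sign that this ring tolerates some changes less well than others. Chloro in place of hydrogen gives a 1.0-fold higher number from compound 1 to compound 3 (0.02 log units; within the scatter), so this chlorine, unlike the methyl of compound 2, produces no step beyond the scatter. Nothing available explains this difference.

The methyl and the chlorine sit at different places on the ring, so the effect of the group remains tangled with the effect of its place. From the compounds shown here alone, how a methoxy group or an amine would behave on this ring also remains open.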